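Cytotoxicity notes: from compound 2 to compound 3

This account rests on a few compounds, and the source may have more. Where it says the series, first, only, none or still open, it means among the compounds named here.

Measured so far in an ADME assay on Akata cells (Homo sapiens) for cytotoxicity, with a stated time of 7 days; on this read-out higher numbers stand for lower toxicity in this test and lower numbers for higher toxicity in this test:
compound 1 `Nc1nc(NCc2ccccc2)c2ncn(/C=C3/CC3(CO)CO)c2n1` — > 24000 nM, a limit of the assay
compound 2 `Nc1nc(N2CCCC2)c2ncn(/C=C3/CC3(CO)CO)c2n1` — > 24000 nM, a limit of the assay

Both values sit at the limit of > 24000 nM in this assay, at which 2 of the 2 values shown sit, so compound 2 stands at the assay limit with no number of its own. For the measured compounds named here, the only measured step, a step that the two limits leave unreadable from compound 1 to compound 2, is unreadable and gives no size to compare. Compound 3 `CC(C)Sc1nc(N)nc2c1ncn2/C=C1/CC1(CO)CO` differs from compound 2 by isopropylsulfanyl in place of pyrrolidin-1-yl on an aromatic carbon. Going by the values given here, no measured step bears on this change. Because both values sit at the limit of > 24000 nM in this assay, at which 2 of the 2 values shown sit, compound 3 is expected to return a limit as well. The expected step that the limit leaves unreadable from compound 2 to compound 3 is no change beyond the scatter. The estimate for compound 3 is 30000 nM, within 10000 nM to 100000 nM.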

Compound 3, half-maximal cytotoxic concentration: > 20000 nM
Compound 3 gave a limit, no number; the forecaster's own chance of this, stated with the estimate: 80%; the middle value does not contradict the limit.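

For the compounds shown here, compound 1, compound 2 and compound 3 all sit at limits of the assay, so no step among them can be read. The compounds shown leave open whether any group at this aromatic carbon gives a measurable value in this assay.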